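Antiproliferative readings on WI-38 cells: from compound 3 to compound 4

The source may report more compounds than this note shows. Statements on the series, on what has been measured and on what is new or still open speak of the compounds shown alone.

Compound 1 `O=C(NCCNc1cc(-c2cn(-c3ccccc3)nc2-c2cccc(O)c2)ccn1)Nc1ccc(Cl)c(Cl)c1`: 17400 nM
Compound 2 `O=C(NCCNc1cc(-c2cn(-c3ccccc3)nc2-c2cccc(O)c2)ccn1)Nc1cccc(C(F)(F)F)c1`: 18500 nM
Compound 3 `O=C(NCCCNc1cc(-c2cn(-c3ccccc3)nc2-c2cccc(O)c2)ccn1)Nc1ccc(F)cc1`: 16800 nM

All three values come from a functional assay on WI-38 cells (Homo sapiens) for antiproliferative activity, read by MTT assay; on this read-out higher numbers stand for weaker inhibition and lower numbers for stronger inhibition. Compound 3, at 16800 nM, lies within the scatter of both other compounds, so the three cannot be ranked.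

Compound 4 `O=C(NCCCNc1cc(-c2cn(-c3ccccc3)nc2-c2cccc(O)c2)ccn1)Nc1cccc(C(F)(F)F)c1` has not yet been measured. It differs from compound 3 in one place: 3-(trifluoromethyl)phenyl in place of 4-fluorophenyl on an amide-type nitrogen. In words, 3-(trifluoromethyl)phenyl stands in place of 4-fluorophenyl on an amide-type nitrogen.

Among the measured compounds shown here, two measured steps bear on this change. The closer one is a 1.1-fold higher number from compound 1 to compound 2 (0.03 log units; within the scatter), which brings in the same 3-(trifluoromethyl)phenyl on an amide-type nitrogen, though in place of 3,4-dichlorophenyl. The other is a 1.0-fold lower number from compound 1 to compound 3 (0.02 log units; within the scatter), which alters the aryl group and the chain together. For the measured compounds named here, the data hold no step that removes 4-fluorophenyl while leaving the chain of compound 3 unchanged, so the evidence is indirect. Neither measured step goes beyond the scatter, and so no step beyond the scatter is expected in this assay here. The expected step is a 1.0-fold higher number from compound 3 to compound 4 (0.02 log units; within the scatter). For compound 4 the estimated value is 17500 nM, with an expected range from 11000 nM to 28000 nM.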

Compound 4, half-maximal inhibitory concentration: 13600 nM
Beside the measured number, compound 4's estimate is 1.3-fold (0.11 log units) above it, and the stated range covers the measured number.
By their numbers in this assay, from the lowest: compounds 4, 3, 1 and 2 (each within the scatter of the next).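

In this assay, 3-(trifluoromethyl)phenyl in place of 4-fluorophenyl on an amide-type nitrogen gives a 1.2-fold lower number from compound 3 to compound 4 (0.09 log units; within the scatter), a direct reading of this exchange with the chain left unchanged. Until now, 3-(trifluoromethyl)phenyl had been seen entering only on the other chain and in place of 3,4-dichlorophenyl, as a 1.1-fold higher number from compound 1 to compound 2 (0.03 log units; within the scatter), so the two steps now show that an exchange of the aryl group at this nitrogen stays within the scatter on both chains, even with 10 heavy atoms entering where 7 leave. No measurement of any property of these groups is available to bear on this result.

Every aryl group shown at this position carries fluorine or chlorine, so the compounds leave open how an unsubstituted phenyl, or a phenyl bearing an amine or a carboxylic acid, would read in this assay. They also leave open whether a longer chain, or a saturated ring in place of the aryl group, would produce any step beyond the scatter.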